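Fluoro for methoxy on the shared core: stability outlook

This account rests on a few compounds, and the source may have more. Where it says the series, first, only, none or still open, it means among the compounds named here.

Compound 2 `COc1nc(N)nc2c1c(-c1ccc3oc(N)nc3c1)nn2C(C)C` stands at a limit in an ADME assay on microsomes from liver (Homo sapiens) for metabolic stability, read by LC-MS, with a stated time of 15 min, tested at 1 uM, in the presence of a further agent that is not named here; a lower number here means that less of the compound is left, a higher number that more of the compound is left: there compound 2 gives > 95%, a limit and not a number. Compound 1 `CC(C)n1nc(-c2ccc3oc(N)nc3c2)c2c(CO)nc(N)nc21` likewise gives > 95% in this assay, again a limit. The step that the two limits leave unreadable from compound 1 to compound 2 is therefore unreadable. Compound 3 `CC(C)n1nc(-c2ccc3oc(N)nc3c2)c2c(F)nc(N)nc21` differs from compound 2 by fluoro in place of methoxy on an aromatic carbon. Within the data shown here, with both known values sitting at the limit (the limit of > 95% in this assay, at which 2 of the 2 values shown sit), no measured step can size this change; it only shows the limit reached twice. Compound 3 is expected to stay near that limit, an expected step of a number no higher from compound 2 to compound 3 (the limit leaves the size open). The estimate for compound 3 is 95%, between 85% and 100%.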

Compound 3, percent of the compound remaining: 83%
Compound 3: the middle estimate sits 12 percentage points above what was measured; measured number outside the range, below it.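

In this assay this position stops being silent: fluoro in place of methoxy gives a number at least 12 percentage points lower from compound 2 to compound 3 (beyond the scatter), and fluoro in place of hydroxymethyl gives a number at least 12 percentage points lower from compound 1 to compound 3 (beyond the scatter). Among these compounds, the group on this aromatic carbon can therefore move the read-out off the limit, which the earlier compounds could not show. Both step sizes remain open-ended, as the other two values are limits: the limit of > 95% in this assay, at which 2 of the 3 values shown sit.

Going by these compounds, whether hydroxymethyl and methoxy truly differ stays open. So does what an amine or a longer chain such as ethoxy would give on this carbon.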